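The compounds below may be only part of what the source reports. "The series", "measured", "known", "first", "only" and "open" are said of these compounds alone.

Compound 1 `Oc1cccc(-c2cc(-c3ccccc3F)cc(-c3cccc(O)c3)n2)c1` and compound 2 `Oc1cccc(-c2cc(-c3ccc(F)cc3)cc(-c3cccc(O)c3)n2)c1` share one core and differ only in where a fluoro sits on a phenyl ring. In a functional assay on HeLa cells (Homo sapiens) for inhibition (on this read-out lower numbers stand for stronger inhibition and higher numbers for weaker inhibition), compound 1 gives 16000 nM, the higher of the two numbers measured, while compound 2 gives 1280 nM in this assay. The step of a 13-fold lower number from compound 1 to compound 2 (1.10 log units; beyond the scatter) is large and lies beyond the scatter.

Compound 3 `Oc1cccc(-c2cc(-c3ccccc3OC(F)(F)F)cc(-c3cccc(O)c3)n2)c1` has not yet been measured in this assay. Compared with compound 1 the change is trifluoromethoxy in place of fluoro on an aromatic carbon, so the group stays on the same aromatic carbon, ortho to a large group, and only its identity changes. For the measured compounds named here, the one measured step, from compound 1 to compound 2, concerns a move of the fluoro to another carbon and does not test a larger group at the same place, so it bears on the present step only loosely. Going by the values given here, with no direct precedent, no step beyond the scatter is expected in this assay, and compound 3 is estimated at 14000 nM with a range from 4000 nM to 50000 nM, a step of a 1.1-fold lower number from compound 1 to compound 3 (0.06 log units; within the scatter) from compound 1 that is expected rather than known.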

Compound 3, half-maximal inhibitory concentration: 16700 nM
Compound 3: middle estimate off by 1.2-fold (0.08 log units), on the low side, within the range that was stated.
By their numbers in this assay, from the lowest: compound 2; then compounds 1 and 3 (each within the scatter of the next).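

In this assay, trifluoromethoxy in place of fluoro on an aromatic carbon ortho to a large group gives a 1.0-fold higher number from compound 1 to compound 3 (0.02 log units; within the scatter), so compound 1 and compound 3 stand within the scatter of each other. The earlier step, a 13-fold lower number from compound 1 to compound 2 (1.10 log units; beyond the scatter), showed only what moving the fluoro to another carbon does, whereas this pair holds the carbon fixed and shows that a group of 5 heavy atoms, with 1 hydrogen-bond acceptor, reads the same here as a single fluorine. No measurement available here explains why the two groups give such similar numbers.

This covers only two groups at this carbon, so the compounds shown leave open whether an amine, a carboxylic acid or a longer alkyl chain there would also stay within the scatter of compound 1. They also leave open whether trifluoromethoxy on the carbon that carries the fluoro in compound 2 would match that compound, a question that neither of the two steps can settle.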